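Cytotoxicity of chromone acrylamides: from compound 3 to compound 4

A few compounds are considered here, and "the series" means these few. Any claim that something is new, unique, unknown or untested is made for them only; others in the source may bear on it.

Measured so far:
- Compound 1, `COc1ccc2c(=O)c(/C=C/C(=O)Nc3ccc(Cl)cc3)coc2c1`: 272000 nM
- Compound 2, `COc1ccc2c(=O)c(/C=C/C(=O)NCc3ccc(F)cc3)coc2c1`: 133000 nM
- Compound 3, `COc1ccc2c(=O)c(/C=C/C(=O)Nc3ccccc3OC)coc2c1`: 1050000 nM

In an ADME assay on HepG2 2.2.15 cells (Homo sapiens) for cytotoxicity, read by MTT assay, with stated times of 48 h and 9 days (on this read-out higher numbers stand for lower toxicity in this test and lower numbers for higher toxicity in this test), compound 3 gives the highest of the three numbers. Its nearest neighbour is compound 1, with a 3.9-fold higher number from compound 1 to compound 3 (0.59 log units; beyond the scatter), and the furthest is compound 2, with a 7.9-fold higher number from compound 2 to compound 3 (0.90 log units; beyond the scatter). Between compounds 1 and 2 the step was a 2.0-fold lower number from compound 1 to compound 2 (0.31 log units; beyond the scatter).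

Compound 4, `COc1ccc2c(=O)c(/C=C/C(=O)NCc3ccc(F)cc3F)coc2c1`, differs from compound 3 in one place: 2,4-difluorobenzyl in place of 2-methoxyphenyl on an amide-type nitrogen

Among the measured compounds shown here, the step that bears most directly on this change is the one between compound 2 and compound 3, since compound 2 carries a 4-fluorobenzyl on the same amide-type nitrogen and compound 4 carries a 2,4-difluorobenzyl. That step was modest but beyond the scatter, and going from compound 3 to compound 4 moves in the opposite direction. Compound 4 is therefore expected to show a lower number in this assay, estimated as a 7.0-fold lower number from compound 3 to compound 4 (0.85 log units; beyond the scatter), landing near compound 2 because compound 2 gave 133000 nM. The estimate for compound 4 is 150000 nM, with a range from 50000 nM to 500000 nM.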

Compound 4, half-maximal cytotoxic concentration: 79300 nM
Compound 4: the middle estimate sits 1.9-fold (0.28 log units) above what was measured; the range from low to high includes it.
By their numbers in this assay, from the lowest: compounds 4 and 2 (each within the scatter of the next); then compound 1; then compound 3.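

In this assay the 2,4-difluorobenzyl group on the amide-type nitrogen gives a 13-fold lower number from compound 3 to compound 4 (1.12 log units; beyond the scatter) and so the largest step yet at this position, and it also gives a 3.4-fold lower number from compound 1 to compound 4 (0.54 log units; beyond the scatter) as a further step beyond the scatter. Against the 4-fluorobenzyl group, however, a 1.7-fold lower number from compound 2 to compound 4 (0.22 log units; within the scatter) is the first step here that stays within the scatter, so the added fluoro does not separate these two benzyl compounds. Nothing shown accounts for these steps.

Only compound 2 and compound 4 carry a benzyl group, so the compounds shown leave open whether the low numbers belong to benzyl groups in general or to their fluoro substituents. Going by these compounds, it also remains open whether an unsubstituted benzyl, a morpholine or a longer chain on the same nitrogen would fall with compound 2 and compound 4 or with compound 3.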